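Swapping a Benzylsulfanyl Arm for Piperidine on a Nucleoside

The compounds below may be only part of what the source reports. "The series", "measured", "known", "first", "only" and "open" are said of these compounds alone.

Three nucleoside-like compounds have been tested in a functional assay on Huh-7 cells (Homo sapiens) for cytotoxicity, read by MTT assay, with a stated time of 3 days; a higher number here means that more compound is tolerated, a lower number that less compound is tolerated. Compound 1 `OC[C@H]1O[C@@H](n2cnc3c(CS)ncnc32)C[C@@H]1O` gives 41000 nM. Compound 2 `OC[C@H]1O[C@@H](n2cnc3c(CSCc4ccccc4)ncnc32)[C@H](O)[C@@H]1O` reaches only a limit of the measurement, > 100000 nM. Compound 3 `CC(=O)N(Cc1ncnc2c1ncn2[C@H]1C[C@H](O)[C@@H](CO)O1)C1CCCCC1` likewise stops at a limit, > 100000 nM. Compound 2 thus stands at the limit of > 100000 nM in this assay, at which 2 of the 3 values shown sit, with only compound 1 giving a real number. Compound 4 `OC[C@H]1O[C@@H](n2cnc3c(CN4CCCCC4)ncnc32)[C@H](O)[C@@H]1O` is not yet measured; it differs from compound 2 in one place: piperidin-1-yl in place of benzylsulfanyl on a saturated chain carbon bound to an aromatic carbon. Among the measured compounds shown here, no pair of measured compounds differs in a single place, so no size of effect in this assay is known for any change here. The step of a number no higher from compound 2 to compound 4 (the limit leaves the size open) is expected to be no larger than the usual scatter. Compound 4 is estimated at 100000 nM, within 30000 nM to 250000 nM.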

Compound 4, half-maximal cytotoxic concentration: 87000 nM
Estimate against measurement, compound 4: 1.1-fold (0.06 log units) above; low and high end bracket the measured number.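

In this assay, piperidin-1-yl in place of benzylsulfanyl on this saturated chain carbon gives an at least 1.1-fold lower number from compound 2 to compound 4 (0.06 log units; that floor lies within the scatter). Compound 4 gives 87000 nM, a real number that the assay could read. Compound 2 has a limit and not a number, so the true size of this step stays open: the limit of > 100000 nM in this assay, at which 2 of the 4 values shown sit.

The compounds shown leave open how an open-chain amine such as dimethylamino, or a carboxylic acid, would read at this place. They also leave open whether piperidin-1-yl would give a similar step on the core of compound 1.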